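The compounds below may be only part of what the source reports. "The series", "measured", "known", "first", "only" and "open" are said of these compounds alone.

Compounds measured so far in an assay on isolated protein for inhibition of long-chain fatty acid transport protein 1 (Mus musculus); a lower number here means a stronger inhibitor, a higher number a weaker inhibitor:

compound 1 `CCn1c(CNc2ccccc2)nnc1SCC(=O)Nc1ccc(Cl)cc1` — > 10000 nM; this is a limit of this assay, not a number
compound 2 `CCn1c(CNc2ccccc2)nnc1SCC(=O)Nc1ccc(C(=O)OC)cc1` — "not determined" (no result reported)
compound 3 `CCOC(=O)c1ccc(NC(=O)CSc2nnc(CNc3ccccc3)n2CC)cc1` — 1100 nM

Among the measured compounds shown here, compound 3 carries the only numerical value in this assay. Compound 1 sits at the limit (the limit of > 10000 nM in this assay, at which 1 of the 3 values shown sits), and compound 2 has no result. For the measured compounds named here, the one measured step, an at least 9.0-fold lower number from compound 1 to compound 3 (0.95 log units; beyond the scatter), concerns the aromatic substituent at the amide end of the shared core and leaves the other end of the molecule untouched.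

Compound 4 `CCOC(=O)c1ccc(NC(=O)CSc2nnc(CSCc3ccccc3)n2CC)cc1` differs from compound 3 at that other end: benzylsulfanyl in place of anilino on a saturated chain carbon bound to an aromatic carbon. Going by the values given here, no measured step touches this part of the core; the step from compound 1 to compound 3 concerns a different position and gives no guidance on the direction here. The change removes the single hydrogen-bond donor counted in the leaving group and replaces nitrogen with sulfur, but no measurement in the series shows what this does in this assay.

Among the compounds with values here, with no step to rest on, the expectation for compound 4 is set near compound 3, with a wide range to both sides: an estimated step of a 1.8-fold higher number from compound 3 to compound 4 (0.26 log units; within the scatter). The estimate for compound 4 in this assay is 2000 nM, ranging from 400 nM to 10000 nM.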

Compound 4, half-maximal inhibitory concentration: > 10000 nM
Compound 4: a limit, no number; the forecaster's own chance of this, stated with the estimate: 30%; middle value at least 5.0-fold (0.69 log units) from the limit.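

In this assay compound 4 gives > 10000 nM, which is a limit of the assay and not a number. Among the compounds shown here, replacing anilino with benzylsulfanyl on a saturated chain carbon bound to an aromatic carbon gives an at least 9.0-fold higher number from compound 3 to compound 4 (0.95 log units; beyond the scatter), the first measured evidence that this end of the molecule, and not only the aromatic substituent at the amide end, matters in this assay. Compound 3 remains the only compound with a number, and a single change at either end of it leads to a compound at the limit: the limit of > 10000 nM in this assay, at which 2 of the 4 values shown sit.

This one step changes several things at once, so the compounds shown do not separate the effect of sulfur in place of nitrogen, the absence of anilino's hydrogen-bond donor, and the benzyl group in place of the phenyl ring; benzylamino and phenylsulfanyl at the same place would pull these apart. Also open, on these data alone, is how far compound 4 lies past the limit, and whether any group at this place, such as a morpholine or a carboxylic acid, can match or improve on anilino.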